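This account rests on a few compounds, and the source may have more. Where it says the series, first, only, none or still open, it means among the compounds named here.

Measured compounds:
- compound 1 `CCc1cnc(N2CCC(c3nc(COc4ccc(/C=C5\SC(=O)NC5=O)cc4F)cs3)CC2)nc1`: 780 nM
- compound 2 `CCc1cnc(N2CCC(c3nc(COc4ccc(/C=C/C(=O)O)cc4F)cs3)CC2)nc1`: "not determined" (no result reported)
- compound 3 `CCc1cnc(N2CCC(c3nc(COc4ccc(/C=C5\SC(=S)N(N)C5=O)cc4F)cs3)CC2)nc1`: "not determined" (no result reported)

Going by the values given here, in a functional assay on cells for agonist activity at Glucose-dependent insulinotropic receptor (Homo sapiens), read by a luciferase reporter, with a stated time of 6 h (a higher number here means that more compound is needed for the effect, a lower number that less compound is needed), compound 1 gives 780 nM, and this is the only number the set holds. Compound 2 is recorded without a result in this assay, and compound 3 likewise stands without a number; nothing can be said of where compound 3 lies relative to compound 1 beyond the fact that no value was reported for it. The shared core, visible in the structure of compound 1, carries a fluorinated aromatic ring whose terminal group is what varies across the set.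

Compound 4 `CCc1cnc(N2CCC(c3nc(COc4ccc(/C=C5\CCNC5=O)cc4F)cs3)CC2)nc1` differs from compound 3 by a group of 7 heavy atoms (5 carbon, 1 nitrogen, 1 oxygen; one five-membered non-aromatic ring with 1 hetero atom) in place of a group of 9 heavy atoms (4 carbon, 2 nitrogen, 1 oxygen, 2 sulfur; one five-membered non-aromatic ring with 2 hetero atoms), on an aromatic carbon. Among the compounds with values here, no measured pair shows this kind of change, and compound 3 has no number to step from, so the size and direction of the step in this assay cannot be read from the data; with only compound 1 as an anchor, a step beyond the scatter in either direction is possible. Compound 4 is expected to give about 1500 nM, estimated between 400 nM and 6000 nM.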

Compound 4, half-maximal effective concentration: 100 nM
Estimate against measurement, compound 4: 15-fold (1.18 log units) above; the whole stated range lies above it.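

In this assay, going by these compounds alone, the position on the aromatic carbon para to a large group and meta to a fluoro group proves responsive to the group it carries, a change that no earlier pair could show: the replacement gives a 7.8-fold lower number from compound 1 to compound 4 (0.89 log units; beyond the scatter). The five-membered non-aromatic ring with 1 hetero atom thus needs less compound for the effect than the five-membered non-aromatic ring with 2 hetero atoms, so the ring sulfur and one of the two oxygens of the group in compound 1 are not required for activity at this level. No measurement is available that would explain the difference between these two groups.

As far as these compounds go, compound 2 and compound 3 stand without a number, so the steps from them to compound 4 cannot be read, and it remains open how their terminal groups rank against the two measured rings. Also open, from the compounds shown here alone, is how a methyl group on the ring nitrogen, a six-membered ring in place of the five-membered one, or a simple amine would behave at this position.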